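From one fluorine to three on the phenoxy group

This account rests on a few compounds, and the source may have more. Where it says the series, first, only, none or still open, it means among the compounds named here.

Measured so far in a functional assay on Jurkat cells (Homo sapiens); on this read-out higher numbers stand for weaker inhibition and lower numbers for stronger inhibition:
Compound 1, `CC(C)[C@H](NC(=O)COc1cccc2ccccc12)C(=O)N[C@@H](CC(=O)O)C(=O)COc1ccccc1`, gives 14000 nM.
Compound 2, `CC(C)[C@H](NC(=O)COc1cccc2ccccc12)C(=O)N[C@@H](CC(=O)O)C(=O)COc1ccc(C(N)=O)cc1`, reaches only the limit of the assay, > 100000 nM.
Compound 3, `CC(C)[C@H](NC(=O)COc1cccc2ccccc12)C(=O)N[C@@H](CC(=O)O)C(=O)COc1ccccc1F`, likewise reaches only the limit of the assay, > 100000 nM.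

Compound 3 therefore stands at the limit of > 100000 nM in this assay, at which 2 of the 3 values shown sit, with no number of its own. Its step from the parent is an at least 7.1-fold higher number from compound 1 to compound 3 (0.85 log units; beyond the scatter), and the same kind of step is seen in an at least 7.1-fold higher number from compound 1 to compound 2 (0.85 log units; beyond the scatter). The pair compound 2 and compound 3 gives a step that the two limits leave unreadable from compound 2 to compound 3.

Compound 4, `CC(C)[C@H](NC(=O)COc1cccc2ccccc12)C(=O)N[C@@H](CC(=O)O)C(=O)COc1ccc(F)c(F)c1F`, differs from compound 3 in one place: 2,3,4-trifluorophenyl in place of 2-fluorophenyl on an oxygen on a saturated carbon. For the measured compounds named here, no measured step covers this change; the only fluorine step known, an at least 7.1-fold higher number from compound 1 to compound 3 (0.85 log units; beyond the scatter), already ran to the limit. Since compound 3 is itself at the limit, the step in this assay is expected to be a number no higher from compound 3 to compound 4 (the limit leaves the size open), which here means no movement that the assay could read. Compound 4 is thus expected to report 100000 nM, within a range from 30000 nM to 300000 nM, and most likely to return only a limit again.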

Compound 4, half-maximal inhibitory concentration: 35800 nM
For compound 4 the middle estimate is 2.8-fold (0.45 log units) above the measured one; the measured number falls inside the stated range.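

In this assay, the 2,3,4-trifluorophenyl group brings back a readable value, with an at least 2.7-fold lower number from compound 3 to compound 4 (0.44 log units; beyond the scatter), and the comparison with the 4-carbamoylphenyl group runs the same way, with an at least 2.7-fold lower number from compound 2 to compound 4 (0.44 log units; beyond the scatter). The single-fluorine result therefore did not predict the three-fluorine result, and fluorine on this phenoxy group does not in itself take a compound to the limit, although the plain phenyl group keeps the lower number, with a 2.6-fold higher number from compound 1 to compound 4 (0.41 log units; beyond the scatter). The true size of the first two steps stays open because each starts from a value that is only a limit: the limit of > 100000 nM in this assay, at which 2 of the 4 values shown sit.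

The compounds shown leave open which of the added fluorines carries the change, and whether the 2-fluorophenyl result and the 2,3,4-trifluorophenyl result depend on the number of fluorines or on where they sit. From the compounds shown here alone, whether a chloro or a methoxy group on the same phenoxy group would give a value nearer to that of compound 1 or to that of compound 4 also remains open.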